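Swapping One Side Group on Compound 1

The source may hold more compounds than are shown below. What is called first, only, known or untested is meant among the compounds shown, and "the series" means these compounds.

Among the compounds with values here, in a functional assay on MCF7 cells (Homo sapiens) for cytotoxicity, read by sulforhodamine B assay, with a stated time of 72 h (on this read-out higher numbers stand for weaker inhibition and lower numbers for stronger inhibition), compound 1 (`O=C(Nc1ccc(Nc2ncnc3c2cnn3-c2ccccc2)cc1)Nc1cccc(Cl)c1`) gives 4200 nM and so holds the lower of the two numbers known, which here means the stronger inhibition. Compound 2 (`O=C(Nc1ccccc1)Nc1ccc(Oc2ncnc3c2cnn3-c2ccc(Cl)cc2)cc1`) gives 82500 nM as the higher number, a gap beyond the usual scatter. The two differ in more than one place, so this gap says nothing about any single change. Compound 3 (`O=C(Nc1cccc(Cl)c1)c1ccc(Nc2ncnc3c2cnn3-c2ccccc2)cc1`) has (3-chlorophenyl)carbamoyl in place of ((3-chlorophenyl)carbamoyl)amino on an aromatic carbon and otherwise keeps the structure of compound 1. Within the data shown here, no measured pair shows this swap, so the expectation starts from compound 1 at 4200 nM and stays wide. The estimated change is a small weakening toward a higher number, a 2.1-fold higher number from compound 1 to compound 3 (0.33 log units; beyond the scatter) in this assay and about at the edge of the scatter. Compound 3 is expected at 9000 nM with 2500 nM to 32000 nM as the likely range.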

Compound 3, half-maximal inhibitory concentration: 1120 nM
Compound 3: middle estimate off by 8.0-fold (0.91 log units), on the high side; the measured number lies below the stated range.
By their numbers in this assay, from the lowest: compound 3; then compound 1; then compound 2.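

Compound 1 and compound 2 differ in more than one place, so they could not isolate any single change, but this new pair can. In this assay, putting (3-chlorophenyl)carbamoyl in place of ((3-chlorophenyl)carbamoyl)amino on this aromatic carbon, para to a large group, gives a 3.8-fold lower number from compound 1 to compound 3 (0.57 log units; beyond the scatter) and so a modest gain in inhibition, which shows that this position accepts a group with fewer heavy atoms and fewer hydrogen-bond donors without losing activity. No measurement at hand explains why the number falls.

On these data alone, whether an amine, a carboxylic acid or a longer chain at this position would give a lower or a higher number stays open. As far as these compounds go, it is also open whether the same swap would shift the number similarly on a compound whose other parts differ, such as compound 2.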